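This account rests on a few compounds, and the source may have more. Where it says the series, first, only, none or still open, it means among the compounds named here.

Working notes on the series.

Compound 1 `N#CCNC(=O)[C@@H]1CN(S(=O)(=O)c2ccccc2)C[C@H]1C(=O)N1CCOCC1` is the reference point. In a functional assay on A20 cells (Mus musculus) for inhibition, with stated times of 1 h, 16 h and 24 h (on this read-out higher numbers stand for weaker inhibition and lower numbers for stronger inhibition), compound 1 gives 4240 nM. Compound 2 `N#CCNC(=O)[C@@H]1CN(S(=O)(=O)c2ccccc2Cl)C[C@H]1C(=O)N1CCOCC1` carries one change relative to compound 1, (chloro in place of hydrogen on an aromatic carbon). In this assay compound 2 gives 208 nM, and the step of a 20-fold lower number from compound 1 to compound 2 (1.31 log units; beyond the scatter) is the largest effect seen among the measured compounds.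

Compound 3 `N#CC1(NC(=O)[C@@H]2C[C@@H](S(=O)(=O)c3ccccc3)CN2C(=O)c2ccccc2)CC1` has a different core; the difference between the core of compound 1 and the core of compound 3 is not broken down here. In this assay compound 3 gives 217 nM, which sits within the scatter of the value of compound 2.

Compound 4 `N#CC1(NC(=O)[C@@H]2C[C@@H](S(=O)(=O)c3ccccc3Cl)CN2C(=O)c2ccccc2)CC1` is not yet measured. It differs from compound 3 by chloro in place of hydrogen on an aromatic carbon, the same change as that from compound 1 to compound 2, at a place described in the same words. Going by the values given here, for compound 4 the expected step is a 7.2-fold lower number from compound 3 to compound 4 (0.86 log units; beyond the scatter), because the single prior example of this change gave a 20-fold lower number from compound 1 to compound 2 (1.31 log units; beyond the scatter), with some allowance made since that example sits on a different core. On this basis the estimate for compound 4 in this assay is 30 nM, with a range from 8 nM to 120 nM.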

Compound 4, half-maximal inhibitory concentration: 15 nM
Compound 4: the middle estimate sits 2.0-fold (0.30 log units) above what was measured; measured number inside the range.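

In this assay, chloro in place of hydrogen on the phenylsulfonyl group of the second core gives a 14-fold lower number from compound 3 to compound 4 (1.16 log units; beyond the scatter), again a large step. Set beside the earlier example, the change carries from one core to the other with no difference that can be told apart: the same change on two cores in this assay, a 20-fold lower number (1.31 log units; beyond the scatter) from compound 1 to compound 2 and a 14-fold lower number (1.16 log units; beyond the scatter) from compound 3 to compound 4, 1.4-fold (0.15 log units) apart, within the scatter of two such steps. Going by these compounds alone, this rests on only two matched pairs and holds only for phenylsulfonyl to (2-chlorophenyl)sulfonyl on these two cores, so it does not show that the step would hold on any other core, and it gives no reason for its size.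

The compounds shown leave open whether fluoro, bromo, methyl or methoxy in the same place would give a step of similar size. Also open, going by these compounds, is whether the step survives when the benzoyl group of compound 4 gives way to another acyl group or the nitrile-bearing amide side chain is changed.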